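A few compounds are considered here, and "the series" means these few. Any claim that something is new, unique, unknown or untested is made for them only; others in the source may bear on it.

Of the compounds shown here, three built on the same core have been measured in a functional assay (brain) for inhibition, with Rattus norvegicus as the target; on this read-out lower numbers stand for stronger inhibition and higher numbers for weaker inhibition. Compound 1 `Cc1c(C)c2c(c(C)c1O)CCC(C)(C(=O)N1CCCC1)O2` gives 10000 nM. Compound 2 `Cc1c(C)c2c(c(C)c1O)CCC(C)(CN1CCCC1)O2` gives 1400 nM in this assay, and the step of a 7.1-fold lower number from compound 1 to compound 2 (0.85 log units; beyond the scatter) comes from (pyrrolidin-1-yl)methyl in place of (pyrrolidin-1-yl)carbonyl on a saturated ring carbon. Compound 3 `Cc1c(C)c2c(c(C)c1O)CCC(C)(CNc1ccccn1)O2` gives 200 nM in this assay, the lowest of the three numbers, and the step of a 7.0-fold lower number from compound 2 to compound 3 (0.85 log units; beyond the scatter) comes from (pyridin-2-yl)amino in place of pyrrolidin-1-yl on a saturated chain carbon bound to a saturated ring carbon.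

Compound 4 `Cc1c(C)c2c(c(C)c1O)CCC(C)(CNCCN(C)C)O2` has not yet been measured. It differs from compound 3 by 2-(dimethylamino)ethyl in place of pyridin-2-yl on an amine nitrogen. Neither measured step touched this amine nitrogen, so no direct guide exists; the nearest comparison is the step from compound 2 to compound 3, which also reshaped the group on the saturated chain carbon, yet it introduced the ring that now leaves. A modest rise in the number is expected, so the step of a 4.0-fold higher number from compound 3 to compound 4 (0.60 log units; beyond the scatter) is the estimate. Compound 4 is estimated at 800 nM, with a range from 200 nM to 3000 nM in this assay.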

Compound 4, half-maximal inhibitory concentration: 1700 nM
For compound 4 the middle estimate is 2.1-fold (0.33 log units) below the measured one, and the stated range covers the measured number.
By their numbers in this assay, from the lowest: compound 3; then compounds 2 and 4 (each within the scatter of the next); then compound 1.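

In this assay, what sits on the amine nitrogen clearly matters: 2-(dimethylamino)ethyl in place of pyridin-2-yl gives a clear rise (an 8.5-fold higher number from compound 3 to compound 4 (0.93 log units; beyond the scatter)), so an amine nitrogen at this place does not by itself give the low number of compound 3. The open chain instead stands level with the pyrrolidin-1-yl group (a 1.2-fold higher number from compound 2 to compound 4 (0.08 log units; within the scatter)), while it remains clearly apart from the carbonyl-linked group of compound 1 (a 5.9-fold lower number from compound 1 to compound 4 (0.77 log units; beyond the scatter)). Nothing measured here gives a reason for these differences.

Still open, on these data alone, is whether the low number of compound 3 depends on the aromatic ring as such or on the nitrogen within it, a question that phenyl on the same amine nitrogen would address. Also open, as far as these compounds go, is how a longer chain ending in a dimethylamino group would compare with 2-(dimethylamino)ethyl.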